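This account rests on a few compounds, and the source may have more. Where it says the series, first, only, none or still open, it means among the compounds named here.

In a functional assay on MDA-MB-231 cells (Homo sapiens) for antiproliferative activity, read by MTT assay (a lower number here means a stronger inhibitor, a higher number a weaker inhibitor), three compounds have been measured so far

compound 1 `CCCCC/C=C\C/C=C\CCCCCCCc1cc(=O)c2c(O)c(C)c(OCOC)c(C)c2o1` gives 16100 nM
compound 2 `CCCCC/C=C\C/C=C\CCCCCCCc1cc(=O)c2c(O)cc(OCOC)c(C)c2o1` gives 16100 nM
compound 3 `CCCCC/C=C\C/C=C\CCCCCCCc1cc(=O)c2c(O)c(C)c(O)c(C)c2o1` gives 16100 nM

In this assay, going by the values given here, compound 2 and compound 3 stand level with compound 1 at 16100 nM on the numbers so far. Compound 4 `CCCCCCCCCCCCCCCc1cc(=O)c2c(O)c(C)c(OCOC)c(C)c2o1` keeps the core of compound 1 and alters only the chain octyl in place of deca-1,4-dien-1-yl on a saturated chain carbon, seven bonds along the chain from an aromatic carbon with octyl in place of deca-1,4-dien-1-yl. The two measured steps leave the chain alone and show no change at the digits printed from compound 1 to compound 2 (within the scatter) and no change at the digits printed from compound 1 to compound 3 (within the scatter) as their result. Among the compounds with values here, no step on the chain has been measured, so they are only a loose guide, and no step beyond the scatter is expected. The expected step is no change at the digits printed from compound 1 to compound 4 (within the scatter) on this estimate. For compound 4 the estimated value is 16100 nM with an expected range from 7000 nM to 35000 nM as a best guess.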

Compound 4, half-maximal inhibitory concentration: > 87000 nM
Compound 4: a limit, no number; the forecaster's own chance of this, stated with the estimate: 25%; at least 5.4-fold (0.73 log units) between middle value and limit.
By their numbers in this assay, from the lowest: compounds 1, 2 and 3 (each within the scatter of the next). At a limit, above all of these: compound 4.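

Going by these compounds alone, the chain is the first place where a change moves the result in this assay: octyl in place of deca-1,4-dien-1-yl gives an at least 5.4-fold higher number from compound 1 to compound 4 (0.73 log units; beyond the scatter) on a saturated chain carbon, seven bonds along the chain from an aromatic carbon. This part of the molecule therefore responds to change, unlike the two places altered in compound 2 and compound 3. The value of compound 4 is a limit and not a number: the limit of > 87000 nM in this assay, at which 1 of the 4 values shown sits.

The compounds shown cannot tell whether losing the double bonds or shortening the chain counts. Decyl in this place, or an amine at the chain end, remains open.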